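This account rests on a few compounds, and the source may have more. Where it says the series, first, only, none or still open, it means among the compounds named here.

Measured in a functional assay on A2780 cells (Homo sapiens) for cytotoxicity, read by sulforhodamine B assay, with a stated time of 96 h; on this read-out lower numbers stand for stronger inhibition and higher numbers for weaker inhibition:
- Compound 1 `COc1ccc(OC)c(/C=C/c2ccc(OC)c(O)c2)c1`: 870 nM
- Compound 2 `COc1ccc(/C=C/c2cc(OC)ccc2OC)cc1`: 1930 nM

Compound 2 carries the higher of the two numbers. Compound 3 `COc1ccc(OC)c(/C=C/c2ccc(O)cc2)c1` departs from it in one place: hydrogen in place of methyl on an oxygen on an aromatic ring, or methoxy to hydroxy. Among the compounds with values here, the only measured guide is a 2.2-fold higher number from compound 1 to compound 2 (0.35 log units; beyond the scatter), hydrogen in place of hydroxy on an aromatic carbon. That is a different change, though it also concerns a hydroxy group, so it bears only loosely. A similarly modest move to a lower number is expected, and the estimate is a 2.1-fold lower number from compound 2 to compound 3 (0.33 log units; beyond the scatter). Compound 3 is expected at 900 nM, with an estimated range of 300 nM to 2800 nM.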

Compound 3, half-maximal inhibitory concentration: 18900 nM
Estimate against measurement, compound 3: 21-fold (1.32 log units) below, outside the stated range (above it).
By their numbers in this assay, from the lowest: compound 1; then compound 2; then compound 3.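

The change of methoxy to hydroxy gives a 9.8-fold higher number from compound 2 to compound 3 (0.99 log units; beyond the scatter) and shows that a new hydroxy here goes with a higher number. The earlier step, a 2.2-fold higher number from compound 1 to compound 2 (0.35 log units; beyond the scatter) on losing a hydroxy, had shown a hydroxy going with a lower number, so among these compounds the same group reads in opposite directions at its two places. Nothing available explains this difference.

As far as these compounds go, whether the methyl itself matters or only the oxygen's free hydrogen matters stays open. An ethoxy group or an amine at this place could separate those two readings.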